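The source may hold more compounds than are shown below. What is called first, only, known or untested is meant among the compounds shown, and "the series" means these compounds.

Of the compounds shown here, two sharing a core have been measured in a functional assay on HCT-116 cells (Homo sapiens) for cytotoxicity, read by MTT assay, with a stated time of 48 h, in the presence of a further agent that is not named here; a lower number here means that less compound is needed, a higher number that more compound is needed for the effect. In this assay, compound 1 (`COc1ccc(-c2cc(NNC(=O)Nc3cc(Cl)nc(Cl)c3)nc3c2cnn3C)cc1`) gives 12300 nM and compound 2 (`COc1cc(NC(=O)NNc2cc(-c3ccccc3)c3cnn(C)c3n2)cc(Cl)n1`) gives 31300 nM. Compound 2 thus holds the higher of the two numbers, and its gap to compound 1 lies beyond the scatter. Compound 3 (`Cn1ncc2c(-c3ccccc3)cc(NNC(=O)Nc3cc(Cl)nc(Cl)c3)nc21`) has not yet been measured. It departs from compound 2 in one place: chloro in place of methoxy on an aromatic carbon. With chloro in place of methoxy on an aromatic carbon, 2-chloro-6-methoxypyridin-4-yl becomes 2,6-dichloropyridin-4-yl. The same dichloro group is carried by compound 1, which stands at 12300 nM, although that compound also differs from compound 3 elsewhere. Within the data shown here, no measured pair isolates this exchange, so the expectation rests on that single comparison and remains loose. A move toward a lower number in this assay is expected, of a size close to the edge of the scatter, with the estimated step being a 2.0-fold lower number from compound 2 to compound 3 (0.29 log units; within the scatter). For compound 3 the estimated value is 16000 nM, with an expected range from 7000 nM to 36000 nM.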

Compound 3, half-maximal effective concentration: 6240 nM
Estimate against measurement, compound 3: 2.6-fold (0.41 log units) above; measured number outside the range, below it.
By their numbers in this assay, from the lowest: compounds 3 and 1 (each within the scatter of the next); then compound 2.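

In this assay, among these compounds, the exchange of methoxy for chloro, next to the ring nitrogen, gives a 5.0-fold lower number from compound 2 to compound 3 (0.70 log units; beyond the scatter); this is the first pair to isolate the change, and it shows that this position alone can move the number beyond the scatter, turning 2-chloro-6-methoxypyridin-4-yl into 2,6-dichloropyridin-4-yl. Among the compounds shown here, the other methoxy, the one that separates compound 1 from compound 3, behaves differently: hydrogen in its place gives a 2.0-fold lower number from compound 1 to compound 3 (0.29 log units; within the scatter), which lies within the scatter, so with the 2,6-dichloropyridin-4-yl group present this second exchange cannot be told apart from repeat measurement. Nothing on hand explains why the first exchange moves the number.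

The compounds shown leave open how other groups at this same position, such as a fluoro, an amine or an ethoxy, would compare with chloro and methoxy. They also leave open whether the exchange would give a step of similar size on the core of compound 1, since this change is read here in a single pair.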